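The source may report more compounds than this note shows. Statements on the series, on what has been measured and on what is new or still open speak of the compounds shown alone.

In a functional assay on MCF7 cells (Homo sapiens) for inhibition (a lower number here means a stronger inhibitor, a higher number a weaker inhibitor), compound 1 `C=CCOC1=CC(=O)S[C@]1(C)CCCCCCCC` reads > 50 ug/mL, which is a limit of the assay. Within the data shown here, compound 2 `CCCCCCCC[C@@]1(C)SC(=O)C=C1OC(=O)OC` stands at 10.7 ug/mL, the only actual number so far. Compound 3 `C=CCOC(=O)OC1=CC(=O)S[C@]1(C)CCCCCCCC` differs from compound 2 by vinyl in place of hydrogen on a saturated chain carbon bound to an oxygen next to a carbonyl group, which turns methoxycarbonyl into allyloxycarbonyl. Among the measured compounds shown here, the one measured step, an at least 4.6-fold lower number from compound 1 to compound 2 (0.66 log units; beyond the scatter), puts methoxycarbonyl in place of allyl, so it bears only indirectly on this change. It shows that the series can respond to a change on that oxygen, but it gives no size for this one. No step beyond the scatter is therefore expected in this assay. The estimated step is a 1.1-fold lower number from compound 2 to compound 3 (0.03 log units; within the scatter). For compound 3 the expected value is 10 ug/mL, with an estimated range of 4 ug/mL to 30 ug/mL.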

Compound 3, half-maximal inhibitory concentration: 14.2 ug/mL
Compound 3: the middle estimate sits 1.4-fold (0.15 log units) below what was measured; the range from low to high includes it.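

In this assay vinyl in place of hydrogen on a saturated chain carbon bound to an oxygen next to a carbonyl group gives a 1.3-fold higher number from compound 2 to compound 3 (0.12 log units; within the scatter) and so leaves methoxycarbonyl and allyloxycarbonyl not told apart. Allyloxycarbonyl in place of allyl gives an at least 3.5-fold lower number from compound 1 to compound 3 (0.54 log units; beyond the scatter) and so shows that the lower number seen with methoxycarbonyl also holds with a second group of this kind. Compound 1 stands at a limit, so this step is only a bound: the limit of > 50 ug/mL in this assay, at which 1 of the 3 values shown sits. Still open, going by these compounds, is how far this position accepts change: a longer chain, a phenyl ring or an amine in place of the vinyl would test that against compound 3.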